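The source may report more compounds than this note shows. Statements on the series, on what has been measured and on what is new or still open speak of the compounds shown alone.

Measured compounds in the series:
compound 1 `N#Cc1cnc(NCc2cnccc2C(F)(F)F)cc1N[C@H]1C[C@@H](O)C1`
compound 2 `CNC(=O)[C@H]1CC[C@@H](Nc2cc(NCc3cnccc3C(F)(F)F)ncc2C#N)CC1`

Going by the values given here, in an assay on isolated protein for inhibition of protein kinase C delta type (Homo sapiens), read by TR-FRET, with a stated time of 2 h (on this read-out higher numbers stand for weaker inhibition and lower numbers for stronger inhibition), compound 2 gives 1600 nM, the only number. For compound 1 this assay reports only a limit, > 10000 nM. For compound 1 that value is the limit of > 10000 nM in this assay, at which 1 of the 2 values shown sits. So compound 2 stands as the sole measured anchor for any estimate.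

Among the compounds with values here, the one measured step on this nitrogen, an at least 6.2-fold lower number from compound 1 to compound 2 (0.79 log units; beyond the scatter), shows that the substituent on the nitrogen on the aromatic ring moves the read-out clearly, with the 4-(methylcarbamoyl)cyclohexyl compound the stronger one.

Compound 3 `CC1(C)[C@@H](C(N)=O)C[C@H]1Nc1cc(NCc2cnccc2C(F)(F)F)ncc1C#N` is not yet measured. It differs from compound 2 by 3-carbamoyl-2,2-dimethylcyclobutyl in place of 4-(methylcarbamoyl)cyclohexyl on a nitrogen on an aromatic ring. This step returns to a four-membered ring, as in compound 1, but keeps an amide as in compound 2, and the measured step does not separate the effect of the ring size from that of the amide. On balance a modest weakening is expected, a 1.6-fold higher number from compound 2 to compound 3 (0.19 log units; within the scatter). Compound 3 is estimated at 2500 nM, with a range of 600 nM to 10000 nM, allowing for the chance that this assay again reports only a limit.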

Compound 3, half-maximal inhibitory concentration: 160 nM
Compound 3: the middle estimate sits 16-fold (1.19 log units) above what was measured, and the stated range ends above it.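

In this assay, 3-carbamoyl-2,2-dimethylcyclobutyl in place of 4-(methylcarbamoyl)cyclohexyl gives a 10-fold lower number from compound 2 to compound 3 (1.00 log units; beyond the scatter), so a six-membered ring on this nitrogen is not required for the stronger inhibition seen so far, and a four-membered ring can carry it. Among the two four-membered ring compounds, 3-carbamoyl-2,2-dimethylcyclobutyl in place of 3-hydroxycyclobutyl gives an at least 62-fold lower number from compound 1 to compound 3 (1.79 log units; beyond the scatter), which shows that ring size alone does not set the read-out at this position, although the carbamoyl and the two methyl groups enter together in this step. The size of that second step has no upper end, as compound 1 is known only through a limit: the limit of > 10000 nM in this assay, at which 1 of the 3 values shown sits.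

The compounds shown do not separate the contribution of the carbamoyl from that of the two methyl groups on the cyclobutyl, nor that of the ring from the difference between carbamoyl and methylcarbamoyl. On these data alone, how a carboxylic acid or an amine in place of the carbamoyl on the same cyclobutyl would read also remains open, as does the effect of the two defined stereocentres.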